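This account rests on a few compounds, and the source may have more. Where it says the series, first, only, none or still open, it means among the compounds named here.

Three compounds from this series have been run in a functional assay on KYSE-450 cells (Homo sapiens) for inhibition, read by MTT assay, with a stated time of 48 h (on this read-out higher numbers stand for weaker inhibition and lower numbers for stronger inhibition), so far. Compound 1 `COCC(=O)N(Cc1ccc(OC)c(O)c1)c1cc(OC)c(OC)c(OC)c1` gives 460 nM, the lowest of the three numbers. Compound 2 `COc1ccc(CNc2cc(OC)c(OC)c(OC)c2)cc1Br` returns 39800 nM, and compound 3 `COc1cc(NCc2cccc(O)c2)cc(OC)c1OC` returns 71300 nM. Both of those lie far above compound 1, well beyond the scatter that repeated measurements of this kind show, so compound 1 stands clearly apart from compounds 2 and 3 in this set. Compounds 2 and 3 differ from compound 1 in more than one place, so no single change can be credited for the gap between them.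

Compound 4 `C=CC(=O)N(Cc1ccc(OC)c(O)c1)c1cc(OC)c(OC)c(OC)c1` has not yet been measured. It shares the core of compound 1 and differs from it in one place: vinyl in place of methoxymethyl on a carbonyl carbon. Nothing in the measured set probes this exact change, so the expectation rests on compound 1 alone. The step from compound 1 to compound 4 is expected to be small, within the scatter or close to it, with no confident direction; the step is estimated as a 1.3-fold lower number from compound 1 to compound 4 (0.12 log units; within the scatter). On that basis compound 4 is estimated at 350 nM in this assay, with a range from 90 nM to 1500 nM.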

Compound 4, half-maximal inhibitory concentration: 160 nM
The estimate for compound 4 lay 2.2-fold (0.34 log units) above the measured number; low and high end bracket the measured number.
By their numbers in this assay, from the lowest: compound 4; then compound 1; then compounds 2 and 3 (each within the scatter of the next).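

In this assay, putting vinyl in place of methoxymethyl on a carbonyl carbon gives a 2.9-fold lower number from compound 1 to compound 4 (0.46 log units; beyond the scatter), a modest step but one beyond the scatter. For the compounds shown here, this is the first comparison that changes only one place, and it shows that the group on this carbonyl carbon can shift the number even when the rest of the molecule stays the same. The swap removes the oxygen of methoxymethyl and brings in a double bond, but no measurement here explains why the number falls.

From the compounds shown here alone, it remains open whether the double bond, the loss of the oxygen or both lie behind the step, and an ethyl group on the same carbonyl carbon would help to separate these possibilities. A longer chain or an amine at this position would show how far the effect extends, while the role of the carbonyl itself cannot be read from compounds 2 and 3, which differ from compound 1 in more than one place.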